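A Second Acetoxy Group Added to an Inactive Core

This account rests on a few compounds, and the source may have more. Where it says the series, first, only, none or still open, it means among the compounds named here.

Compound 2 `CC(=O)Oc1cccc2cc(-c3ccccc3)c(=O)oc12` stands at the limit of a functional assay on CHO cells for antagonist activity at adenosine receptor A2b (Homo sapiens), read by cAMP accumulation (on this read-out lower numbers stand for stronger inhibition and higher numbers for weaker inhibition), with > 30000 nM, a limit rather than a number. Compound 1 `CCOc1cccc2cc(-c3ccccc3)c(=O)oc12` likewise gives only a limit, > 30000 nM. The step from ethyl to acetyl, a step that the two limits leave unreadable from compound 1 to compound 2, cannot be read because both values sit at the limit (the limit of > 30000 nM in this assay, at which 2 of the 2 values shown sit). Compound 3 `CC(=O)Oc1ccc2cc(-c3ccccc3)c(=O)oc2c1OC(C)=O` differs from compound 2 by acetoxy in place of hydrogen on an aromatic carbon. Within the data shown here, no measured step bears on this change, since both values shown are limits. Compound 3 is therefore expected to remain at the limit in this assay, with an expected step that the limit leaves unreadable from compound 2 to compound 3 and an estimate of 40000 nM, ranging from 10000 nM to 150000 nM.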

Compound 3, half-maximal inhibitory concentration: > 30000 nM
Compound 3 ended at the assay's limit; the forecaster's own chance of this, stated with the estimate: 80%; the middle value does not contradict the limit.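

In this assay compound 3 gives > 30000 nM, a limit and not a number, so no step can be read from compound 2 to compound 3: the limit of > 30000 nM in this assay, at which 3 of the 3 values shown sit. Which change to the shared core would bring a measurable value in this assay stays open.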